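Swapping bromo for nitro on a diaryl ether thiosemicarbazone

This account rests on a few compounds, and the source may have more. Where it says the series, first, only, none or still open, it means among the compounds named here.

Measured so far in a physicochemical assay for lipophilicity, in phosphate buffer, measured as octanol-water partition, with a stated time of 24 h; on this read-out lower numbers stand for lower lipophilicity and higher numbers for higher lipophilicity:
- compound 1, `S=C(N/N=C/c1ccc(Oc2ccc(Br)cc2)cc1)Nc1ccccc1`: compound 1 gives 5.62
- compound 2, `S=C(N/N=C/c1ccc(Oc2ccccc2)cc1)Nc1ccc(Br)cc1`: compound 2 gives 6.38
- compound 3, `Cc1ccc(Oc2ccc(/C=N/NC(=S)Nc3ccc(Cl)cc3)cc2)cc1`: compound 3 gives 5.97

Compound 1 has the lowest of the three numbers in this assay. Its nearest neighbour is compound 3, which lies higher by a gap beyond the scatter, and compound 2 lies higher still, also beyond the scatter. No two of these compounds differ in only one place, so none of these gaps can be tied to a single change.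

Compound 4, `O=[N+]([O-])c1ccc(Oc2ccc(/C=N/NC(=S)Nc3ccccc3)cc2)cc1`, has not yet been measured. It differs from compound 1 in one place: nitro in place of bromo on an aromatic carbon. In plain words, nitro replaces bromo on an aromatic carbon, para to a large group.

The step from compound 1 to compound 4 in this assay is expected to be a downward one, beyond the scatter: a number 1.02 log units lower from compound 1 to compound 4 (beyond the scatter). Compound 4 is therefore expected to give about 4.6, with a range from 4 to 5.2.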

Compound 4, partition coefficient: 4.95
Compound 4: the middle estimate sits 0.35 log units below what was measured; the range from low to high includes it.
By their numbers in this assay, from the lowest: compound 4; then compound 1; then compound 3; then compound 2.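

The three earlier compounds each differed in more than one place, so none of their gaps could be tied to a single change. Compounds 1 and 4 now provide that comparison: in this assay, replacing bromo with nitro on an aromatic carbon, para to a large group, gives a number 0.67 log units lower from compound 1 to compound 4 (beyond the scatter). This shows that the group at this position on the core of compound 1 can shift the number by more than the usual scatter. The compounds shown offer no measured evidence that explains the size or direction of this step.

On these data alone, this is a single pair, so it remains open whether the same swap would give a similar step on another core. As far as these compounds go, it also remains open how an amine, a carboxylic acid or a longer chain at this position would compare with bromo and nitro.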